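A few compounds are considered here, and "the series" means these few. Any claim that something is new, unique, unknown or untested is made for them only; others in the source may bear on it.

Measured so far:
compound 1 `Cc1ccc2c(NCc3ccc(NC(=O)C4CCN(Cc5ccccc5)CC4)cc3)nc(N3CCC3)nc2c1`: > 8500 nM
compound 2 `Cc1ccc2c(NCc3ccc(NC(=O)C4CCN(Cc5ccc(Cl)cc5)CC4)cc3)nc(N(C)C)nc2c1`: > 3180 nM
compound 3 `COc1ccc(CN2CCC(C(=O)Nc3ccc(CNc4nc(N(C)C)nc5cc(C)ccc45)cc3)CC2)cc1`: > 6180 nM

In a functional assay on SV5A8 cells (Homo sapiens) for cytotoxicity (a lower number here means a stronger inhibitor, a higher number a weaker inhibitor), compound 1 gives > 8500 nM, which is a limit of the assay and not a number. Compound 2 gives > 3180 nM, again a limit. Compound 3 gives > 6180 nM, also a limit. For the measured compounds named here, compound 2 therefore stands nowhere definite: every value shown is a limit (the limit of > 3180 nM in this assay, at which 1 of the 3 values shown sits, (the limit of > 6180 nM in this assay, at which 1 of the 3 values shown sits), (the limit of > 8500 nM in this assay, at which 1 of the 3 values shown sits)), and no compound can be ordered against another.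

The step to compound 4 `Cc1ccc2c(NCc3ccc(NC(=O)C4CCN(Cc5cccc(F)c5)CC4)cc3)nc(N(C)C)nc2c1` is 3-fluorophenyl in place of 4-chlorophenyl on a saturated chain carbon bound to an amine nitrogen in a ring. Going by the values given here, the only measured step touching the same part of the structure is a step that the two limits leave unreadable from compound 2 to compound 3, which exchanges one substituent on that ring for another; its size is not readable because both ends are limits. Among the compounds with values here, no measured step therefore gives a direction or size for the exchange of 4-chlorophenyl for 3-fluorophenyl, so nothing beyond the scatter can be expected in either direction in this assay, and the most likely outcome is a further limit. Compound 4 is expected at 8000 nM, between 3000 nM and 25000 nM. The expected step that the limit leaves unreadable from compound 2 to compound 4 is, on this evidence, essentially undetermined.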

Compound 4, half-maximal inhibitory concentration: > 4170 nM
Compound 4 ended at the assay's limit; the forecaster's own chance of this, stated with the estimate: 80%; the middle value does not contradict the limit.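

In this assay compound 4 gives > 4170 nM, a limit of the assay and not a number. The steps to compound 4 from compound 2 and from compound 3 have limits at both ends, so neither can be read. The compounds shown leave open whether exchanging the substituted benzyl group changes cytotoxicity at all: every value is a limit.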